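Aryl exchange on the ring nitrogen of compound 1

The source may report more compounds than this note shows. Statements on the series, on what has been measured and on what is new or still open speak of the compounds shown alone.

Three compounds of the shared core have numbers in an assay on Sf9 cells for inhibition of protein deacetylase HDAC6 (Homo sapiens), read by fluorescence, with a stated time of 40 min; a lower number here means a stronger inhibitor, a higher number a weaker inhibitor. Compound 1 `COc1ccc(-n2nc(-c3ccccc3)nc2CNc2ccc(C(=O)NO)cc2)cc1` gives 127 nM. Compound 2 `O=C(NO)c1ccc(NCc2nc(-c3ccc(F)cc3)nn2-c2ccccc2)cc1` gives 115 nM, and compound 3 `O=C(NO)c1ccc(NCc2nc(-c3cc4ccccc4s3)nn2-c2ccccc2)cc1` gives 324 nM. Compound 1 thus holds the second highest of the three numbers: compound 2 sits within the scatter of it, while compound 3 lies higher, beyond the scatter. For the measured compounds named here, the only single-point step measured in the set is a 2.8-fold higher number from compound 2 to compound 3 (0.45 log units; beyond the scatter), a change on an aromatic carbon.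

Compound 4 `Cc1cccc(-n2nc(-c3ccccc3)nc2CNc2ccc(C(=O)NO)cc2)c1` differs from compound 1 as follows: 3-methylphenyl in place of 4-methoxyphenyl on an aromatic nitrogen. Going by the values given here, no measured step touches the group on that ring nitrogen; compounds 1 and 2 differ there but also at the aromatic carbon, so their near-equal numbers give only a loose hint. The step from compound 2 to compound 3 sits at another position and carries over only as a sense of scale for aryl swaps in this core. For compound 4 the step is therefore expected to be small, a 1.0-fold higher number from compound 1 to compound 4 (0.01 log units; within the scatter), with no direction that should clear the scatter. The estimate for compound 4 in this assay is 130 nM, within 60 nM to 280 nM.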

Compound 4, half-maximal inhibitory concentration: 388 nM
The estimate for compound 4 lay 3.0-fold (0.47 log units) below the measured number; the measured number lies above the stated range.
By their numbers in this assay, from the lowest: compounds 2 and 1 (each within the scatter of the next); then compounds 3 and 4 (each within the scatter of the next).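

Notes on the ring nitrogen: this position is not silent in this assay, since the first step measured here is a 3.1-fold higher number from compound 1 to compound 4 (0.49 log units; beyond the scatter), close in size to a 2.8-fold higher number from compound 2 to compound 3 (0.45 log units; beyond the scatter) at the aromatic carbon. For the compounds shown here, the aryl group on the ring nitrogen therefore counts for about as much as the one aryl swap measured on the carbon, and the near-equal numbers of compounds 1 and 2, which differ in two places, gave no reliable reading of it. The step exchanges 4-methoxyphenyl for 3-methylphenyl, so the identity of the substituent, its place on the phenyl ring and the one hydrogen-bond acceptor counted in the leaving group all change at once, and no measured property of these compounds bears on which of these matters.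

Still open, from the compounds shown here alone, is how a 4-methylphenyl or a 3-methoxyphenyl group on the ring nitrogen would read, as either would separate the place of the substituent from its identity. Also open, going by these compounds, is whether the step would hold with 4-fluorophenyl on the aromatic carbon, and how an amine or a carboxylic acid on the nitrogen aryl group would read.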